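A few compounds are considered here, and "the series" means these few. Any claim that something is new, unique, unknown or untested is made for them only; others in the source may bear on it.

Compound 2 `O=c1ccoc2cc(OCc3cn(Cc4ccccc4Br)nn3)ccc12` is one of three close relatives built on a shared core, each differing only in the group attached to a saturated chain carbon bound to an aromatic nitrogen. In a functional assay on MDA-MB-231 cells (Homo sapiens) for cytotoxicity, read by MTT assay, with a stated time of 48 h (a lower number here means a stronger inhibitor, a higher number a weaker inhibitor), compound 2 reaches only the limit > 100000 nM and gives no number. Compound 1 `Cc1cccc(Cn2cc(COc3ccc4c(=O)ccoc4c3)nn2)c1`, carrying 3-methylphenyl in place of 2-bromophenyl, gives 16000 nM in this assay. Compound 3 `CC(C)(C)c1ccc(Cn2cc(COc3ccc4c(=O)ccoc4c3)nn2)cc1` also stops at the limit > 100000 nM in this assay. Going by the values given here, two of the three values therefore sit at the limit of > 100000 nM in this assay, at which 2 of the 3 values shown sit, and the only measured step that bears on compound 2 is an at least 6.2-fold higher number from compound 1 to compound 2 (0.79 log units; beyond the scatter).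

Compound 4 `O=c1ccoc2cc(OCc3cn(Cc4ccccc4)nn3)ccc12` is reached from compound 2 by the change (hydrogen in place of bromo on an aromatic carbon). Since compound 1 shows that a different substituent on this ring can give a measured number (16000 nM), and the step of an at least 6.2-fold higher number from compound 1 to compound 2 (0.79 log units; beyond the scatter) was at least modest, some recovery toward a measurable value seems plausible for compound 4, though compound 3 shows that not every alternative gives a number. Compound 4 is expected to give about 50000 nM in this assay, within 15000 nM to 150000 nM, which would correspond to the estimated step of an at least 2.0-fold lower number from compound 2 to compound 4 (0.30 log units; that floor lies within the scatter).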

Compound 4, half-maximal inhibitory concentration: > 100000 nM
Compound 4: only a limit was reported; the forecaster's own chance of this, stated with the estimate: 40%; middle value at least 2.0-fold (0.30 log units) from the limit.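

Taking the bromo group off does not bring back a number: in this assay compound 4, which carries a plain phenyl, also stops at a limit, > 100000 nM. Among the four compounds shown, only the 3-methylphenyl group gives a measured number, and hydrogen in place of methyl on the aromatic carbon produces an at least 6.2-fold higher number from compound 1 to compound 4 (0.79 log units; beyond the scatter). The steps to compound 4 from compound 2 and from compound 3 join two limits and cannot be read, and the series now stands as follows: the limit of > 100000 nM in this assay, at which 3 of the 4 values shown sit.

From the compounds shown here alone, whether a methoxy group, a chloro group or an amine in the place of that methyl would also give a number remains open. Also open, going by these compounds, is what values compound 2, compound 3 and compound 4 would reach past their limits.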